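The source may report more compounds than this note shows. Statements on the series, on what has been measured and on what is new or still open speak of the compounds shown alone.

Within the data shown here, compound 1 `C=CCn1c(=O)/c(=C\c2cc(F)ccc2C)[nH]c(=O)/c1=C\c1ccccc1OC` gives 3800 nM in a functional assay on MOLT-4 cells (Homo sapiens) for cytotoxicity, read by CCK-8 assay, with a stated time of 72 h (on this read-out higher numbers stand for weaker inhibition and lower numbers for stronger inhibition), the only number in this small set. Compound 2 `C=CCn1c(=O)/c(=C\c2cccc(Br)c2)[nH]c(=O)/c1=C\c1cccc(Br)c1` is reported in this assay as "not active" (no number reported), with no number given. Compound 3 `C=CCn1c(=O)/c(=C\c2cccc(Cl)c2)[nH]c(=O)/c1=C\c1ccccc1OC` differs from compound 1 by 3-chlorophenyl in place of 5-fluoro-2-methylphenyl on a double-bonded chain carbon bound to an aromatic carbon. Among the measured compounds shown here, no measured pair isolates this change, and compound 2 offers no number to set beside it. The expected step is a 1.6-fold higher number from compound 1 to compound 3 (0.20 log units; within the scatter) in this assay, a modest weakening, close to the edge of the scatter. For compound 3 the estimate in this assay is 6000 nM, within 2000 nM to 20000 nM.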

Compound 3, half-maximal inhibitory concentration: 4900 nM
Estimate against measurement, compound 3: 1.2-fold (0.09 log units) above, and the stated range covers the measured number.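

In this assay, 3-chlorophenyl in place of 5-fluoro-2-methylphenyl on a double-bonded chain carbon bound to an aromatic carbon gives a 1.3-fold higher number from compound 1 to compound 3 (0.11 log units; within the scatter). Among these compounds, this is the first comparison between two numbers, and it does not tell the two groups apart. Nothing measured here bears on this result. Still open, going by these compounds, is how an aryl ring carrying an amine or a carboxylic acid would read at this place. Also open, on these data alone, is whether a longer chain in place of the aryl ring would keep the number.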